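A few compounds are considered here, and "the series" means these few. Any claim that something is new, unique, unknown or untested is made for them only; others in the source may bear on it.

Of the compounds shown here, three that share one core have been tested in an assay on isolated protein for inhibition of Voltage-dependent L-type calcium channel subunit alpha-1C (Cavia porcellus); a higher number here means a weaker inhibitor, a lower number a stronger inhibitor. Compound 1, `CCOC(=O)C1=C(C)NC(C)=C(C(=O)OC)C1c1[nH]cnc1Cl`, gives 661 nM. Compound 2, `COC(=O)C1=C(C)NC(C)=C(C(=O)OCCc2ccccc2)C1c1[nH]cnc1Cl`, gives 79.4 nM. Compound 3, `CCOC(=O)C1=C(C)NC(C)=C(C(=O)OC(C)(C)C)C1c1[nH]cnc1Cl`, gives 1660 nM, the highest of the three numbers; compound 1 stands nearest to it and compound 2 furthest from it. Two steps connect the measured compounds. The step of an 8.3-fold lower number from compound 1 to compound 2 (0.92 log units; beyond the scatter) came with a phenyl in place of hydrogen on a saturated chain carbon, two bonds along the chain from an oxygen next to a carbonyl group. The step of a 2.5-fold higher number from compound 1 to compound 3 (0.40 log units; beyond the scatter) came with tert-butyl in place of methyl on an oxygen next to a carbonyl group.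

The step now followed leads from compound 3 to compound 4, `CCOC(=O)C1=C(C)NC(C)=C(C(=O)OCCc2ccccc2)C1c1[nH]cnc1Cl`. The change is phenethyl in place of tert-butyl on an oxygen next to a carbonyl group. Both measured steps bear on it: the step from compound 1 to compound 2 shows what the phenethyl group brought at this place, and the step from compound 1 to compound 3 shows that the tert-butyl group raised the number. Reversing the one and adding the other, compound 4 is expected to show a markedly lower number, an estimated step of an 18-fold lower number from compound 3 to compound 4 (1.27 log units; beyond the scatter). The estimate for compound 4 in this assay is 90 nM, with a range from 30 nM to 270 nM.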

Compound 4, half-maximal inhibitory concentration: 70.8 nM
For compound 4 the middle estimate is 1.3-fold (0.10 log units) above the measured one, and the stated range covers the measured number.
By their numbers in this assay, from the lowest: compounds 4 and 2 (each within the scatter of the next); then compound 1; then compound 3.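

In this assay, exchanging tert-butyl for phenethyl directly on the oxygen next to a carbonyl group gives a large change (a 23-fold lower number from compound 3 to compound 4 (1.37 log units; beyond the scatter)), so this one group separates the two extremes of the series. Compound 4 also lands level with its closest relative (a 1.1-fold lower number from compound 2 to compound 4 (0.05 log units; within the scatter)): with phenethyl present, adding a methyl in place of hydrogen on a saturated chain carbon bound to an oxygen next to a carbonyl group makes no change that can be told from the scatter. The new step from the parent (a 9.3-fold lower number from compound 1 to compound 4 (0.97 log units; beyond the scatter)) shows that phenethyl lowers the number whether it replaces the methyl of compound 1, as here, or its ethyl, as in the earlier step (an 8.3-fold lower number from compound 1 to compound 2 (0.92 log units; beyond the scatter)), and the two products end within the scatter of each other.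

Still open, from the compounds shown here alone, is whether the phenyl ring itself is needed, or whether a plain longer chain such as n-butyl, a phenylpropyl group or a chain ending in an amine would give a similar number. No evidence is available to explain why phenethyl lowers the number here.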